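Diazabicyclic anilinopyridines: chloro to nitro at the aryl para position

The compounds below may be only part of what the source reports. "The series", "measured", "known", "first", "only" and "open" are said of these compounds alone.

Three compounds in the series have numbers. In an assay on cell membranes for displacement of a labelled ligand from Neuronal acetylcholine receptor; alpha4/beta2 (Rattus norvegicus) (a lower number here means a stronger inhibitor, a higher number a weaker inhibitor), compound 1 `Clc1ccc(Nc2ccc(N3CC4CC(C3)N4)nn2)cc1Cl` gives 516 nM, compound 2 `Cc1ccc(Nc2cncc(N3CC4CC(C3)N4)c2)cc1` gives 0.148 nM, and compound 3 `Clc1ccc(Nc2ccc(N3CC4CC(C3)N4)cn2)cc1` gives 2.49 nM. Compound 3 thus stands second highest of the three: its nearest neighbour is compound 2, whose number lies lower by a margin beyond the scatter, and the furthest is compound 1, whose number lies higher by a margin well beyond the scatter. No pair among these three differs in a single place, so no measured single step is available for guidance.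

Compound 4 `O=[N+]([O-])c1ccc(Nc2ccc(N3CC4CC(C3)N4)cn2)cc1` differs from compound 3 by nitro in place of chloro on an aromatic carbon, para to a large group. Among the compounds with values here, for this change no measured precedent exists. For compound 4 in this assay the expected step of a 1.7-fold lower number from compound 3 to compound 4 (0.22 log units; within the scatter) is small, downward if at all, and plausibly within the scatter. Compound 4 is therefore estimated at 1.5 nM, with a range from 0.3 nM to 8 nM.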

Compound 4, inhibition constant: 1.76 nM
Compound 4: middle estimate off by 1.2-fold (0.07 log units), on the low side; low and high end bracket the measured number.
By their numbers in this assay, from the lowest: compound 2; then compounds 4 and 3 (each within the scatter of the next); then compound 1.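

In this assay, the series now has its first measured single step: nitro in place of chloro on an aromatic carbon, para to a large group, gives (a 1.4-fold lower number from compound 3 to compound 4 (0.15 log units; within the scatter)). The two compounds therefore cannot be told apart at this position, even though nitro has more heavy atoms than chloro and brings hydrogen-bond acceptors that chloro lacks. No measurement is available to explain why the two groups read alike.

Whether an amine or a carboxylic acid at this position would read the same as chloro and nitro remains open, since both groups shown leave the number in one narrow place. On these data alone, it also remains open whether nitro in place of chloro would read the same on the core of compound 2 or the core of compound 1.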